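A few compounds are considered here, and "the series" means these few. Any claim that something is new, unique, unknown or untested is made for them only; others in the source may bear on it.

Three compounds on a shared core have numbers in a physicochemical assay, read by HPLC, in phosphate buffer, at pH 7.0; a lower number here means that less of the compound is left, a higher number that more of the compound is left. Compound 1 `O=C(NCCCCCCc1ccccc1)Oc1cccc(-c2ccccc2)c1` gives 61.1%, the highest of the three. Compound 2 `O=C(NCc1cccc2ccccc12)Oc1cccc(-c2ccccc2)c1` gives 24.8%, a gap from compound 1 beyond the scatter; compound 3 `NC(=O)c1cccc(-c2cccc(OC(=O)NCCCCc3ccccc3)c2)c1` gives 18.8%, the furthest from compound 1, also beyond the scatter. Compound 4 `CCCCNC(=O)Oc1cccc(-c2ccccc2)c1` is not yet measured. From compound 1 it differs in one place: hydrogen in place of phenethyl on a saturated chain carbon, four bonds along the chain from an amide-type nitrogen. Among the measured compounds shown here, no measured pair shows this change on its own, so its size is open; compounds 2 and 3 show that other variations on this core sit well below compound 1, which points toward a decrease rather than a gain. Compound 4 is expected to fall somewhat below compound 1, by a step of a number 13.1 percentage points lower from compound 1 to compound 4 (beyond the scatter) that may or may not exceed the scatter. The estimate for compound 4 is 48%, within a range from 25% to 72%.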

Compound 4, percent of the compound remaining: 46.7%
Beside the measured number, compound 4's estimate is 1.3 percentage points above it, and the stated range covers the measured number.
By their numbers in this assay, from the lowest: compounds 3 and 2 (each within the scatter of the next); then compound 4; then compound 1.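

Hydrogen in place of phenethyl gives the first single-place step on the shared core in this assay, a number 14.4 percentage points lower from compound 1 to compound 4 (beyond the scatter), so this position on the saturated chain affects how much compound remains. The step is modest but beyond the scatter, and it rests on this one pair. No available measurement explains it.

From the compounds shown here alone, whether the step follows from losing the aromatic ring or from shortening the chain stays open. A longer chain without a ring, or an amine or carboxylic acid in place of phenethyl, would help separate these readings.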